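Sulfone Replaced by Propyl on a Bicyclic Triazole Scaffold

The compounds below may be only part of what the source reports. "The series", "measured", "known", "first", "only" and "open" are said of these compounds alone.

compound 1 `Cn1c(-c2ccccc2C(F)(F)F)nnc1C12CCC(CCS(C)(=O)=O)(CC1)CC2` gives > 4000 nM
compound 2 `Cn1c(-c2ccccc2C(F)(F)F)nnc1C12CCC(CCS(=O)(=O)C(C)(C)C)(CC1)CC2` gives > 4000 nM
compound 3 `CCS(=O)(=O)CCC12CCC(c3nnc(-c4ccccc4C)n3C)(CC1)CC2` gives > 4000 nM

Of the compounds shown here, three have been measured in an assay on CHO-K1 cells for inhibition of 11-beta-hydroxysteroid dehydrogenase type 2 (Mus musculus), read by scintillation proximity assay (on this read-out higher numbers stand for weaker inhibition and lower numbers for stronger inhibition), and every result recorded so far is a limit of the assay rather than a number. For compound 1 the result is a limit. For compound 2 the result is likewise a limit. For compound 3 as well only a limit was reached. For the measured compounds named here, the single step between compounds that differ in one place, a step that the two limits leave unreadable from compound 1 to compound 2, therefore cannot be sized. Compound 2 stands at that limit together with the other two values, as summarised by the limit of > 4000 nM in this assay, at which 3 of the 3 values shown sit.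

Compound 4 `CCCCCC12CCC(c3nnc(-c4ccccc4C(F)(F)F)n3C)(CC1)CC2` differs from compound 2 by propyl in place of (tert-butyl)sulfonyl on a saturated chain carbon, two bonds along the chain from a saturated ring carbon. Going by the values given here, no measured step bears directly on this change: the only single-place step, a step that the two limits leave unreadable from compound 1 to compound 2, is unreadable, and compound 1 and compound 3, which differ in more than one place, both gave only limits. With every measured compound sitting at the limit, neither a direction nor a size beyond the scatter can be read from the data. Compound 4 is therefore expected to stay near the limit too, which corresponds to an estimated step of a number no higher from compound 2 to compound 4 (the limit leaves the size open). The estimate for compound 4 is 4000 nM, with a range from 1000 nM to 20000 nM.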

Compound 4, half-maximal inhibitory concentration: > 4000 nM
Compound 4: a limit, no number; the forecaster's own chance of this, stated with the estimate: 70%; the middle value lies on the limit itself.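

Compound 4 gives > 4000 nM, a limit of the assay and not a number. Neither its step from compound 1 nor its step from compound 2 can be read, so the position is unchanged: the limit of > 4000 nM in this assay, at which 4 of the 4 values shown sit.

The compounds shown leave open how strongly any of them inhibits the enzyme, and whether exchanging methylsulfonyl, (tert-butyl)sulfonyl and propyl changes inhibition at all.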